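Plasma stability of three macrocycles and one untested analogue

The source may report more compounds than this note shows. Statements on the series, on what has been measured and on what is new or still open speak of the compounds shown alone.

Measured so far:
compound 1 `Cc1oc(=O)oc1COC(=O)N1C[C@@H]2C[C@H]1C(=O)Nc1cccc(c1)C(=O)OCc1oc(=O)oc1COC(=O)C1=C(S2)[C@H](C)[C@@H]2[C@@H]([C@@H](C)O)C(=O)N12` gives 0%;
compound 2 `C[C@@H](O)[C@H]1C(=O)N2C3=C(S[C@@H]4CN[C@@H](C4)C(=O)Nc4cccc(c4)C(=O)OC/C=C\COC3=O)[C@H](C)[C@H]12` gives 21%;
compound 3 `Cc1oc(=O)oc1COC(=O)N1C[C@@H]2C[C@H]1C(=O)Nc1cccc(c1)C(=O)OC/C=C\COC(=O)C1=C(S2)[C@H](C)[C@@H]2[C@@H]([C@@H](C)O)C(=O)N12` gives 20%.

In an ADME assay on a cell-free system (plasma, Homo sapiens) for metabolic stability, read by LC-MS, with a stated time of 60 min, at 37 degrees C, tested at 50 uM (on this read-out lower numbers stand for a less stable compound and higher numbers for a more stable compound), compound 1 gives the lowest value of the three. The same structural change, (a hydrogen atom in place of a group of 11 heavy atoms (6 carbon, 5 oxygen; one five-membered aromatic ring with 2 hetero atoms), on an amine nitrogen in a ring), leads to a number 1 percentage points higher from compound 3 to compound 2 (within the scatter). Compound 4 `C[C@@H](O)[C@H]1C(=O)N2C3=C(S[C@@H]4CN[C@@H](C4)C(=O)Nc4cccc(c4)C(=O)OCc4oc(=O)oc4COC3=O)[C@H](C)[C@H]12` is not yet measured; it differs from compound 1 by a hydrogen atom in place of a group of 11 heavy atoms (6 carbon, 5 oxygen; one five-membered aromatic ring with 2 hetero atoms), on an amine nitrogen in a ring. The two places differ only in the size of the fused or bridged system, six rings rather than five, so this is the same kind of change. The difference between the cores of compound 1 and compound 3 is not broken down here. Because the earlier step was a number 1 percentage points higher from compound 3 to compound 2 (within the scatter), a similar step is expected here: a number 10 percentage points higher from compound 1 to compound 4 (within the scatter), with compound 1 already at the bottom of the scale. Compound 4 is thus estimated at 10%, between 0% and 30%.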

Compound 4, percent of the compound remaining in the plasma assay: 0%
The estimate for compound 4 lay 10 percentage points above the measured number; measured number inside the range.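

In the plasma assay, a hydrogen atom in place of the group of 11 heavy atoms on the amine nitrogen in a ring gives no change at the digits printed from compound 1 to compound 4 (within the scatter). Set beside the earlier step, the change carries from one core to the other without a difference that can be told apart: the same change on two cores in the plasma assay, a number 1 percentage points higher (within the scatter) from compound 3 to compound 2 and no change at the digits printed (within the scatter) from compound 1 to compound 4, 1 percentage points apart, within the scatter of two such steps This rests on only two pairs, and since compound 1 already stands at the bottom of the scale in the plasma assay, it does not show that the change would leave the read-out unmoved on a core with more room to fall.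

In a physicochemical assay for metabolic stability, read by LC-MS, in phosphate buffer, with a stated time of 3 h, at pH 7.4, tested at 50 uM (on this read-out lower numbers stand for a less stable compound and higher numbers for a more stable compound), compound 1 gives > 95%, which is a limit of the assay. In the physicochemical assay compound 4 gives > 95%, which is also a limit of the assay. Going by these compounds, in the physicochemical assay the step between compound 1 and compound 4 cannot be read, as both values are limits of the assay: the limit of > 95% in the physicochemical assay, at which 2 of the 2 values shown sit. It remains open how an acetyl group or a longer alkyl chain on that amine nitrogen would read on these cores.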